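Swapping a Saturated Ring for a Dimethoxyphenyl Group

The source may hold more compounds than are shown below. What is called first, only, known or untested is meant among the compounds shown, and "the series" means these compounds.

Compound 1, `C=C(C)CCOC(=O)C[C@@H]1C(C(=O)OC)=CO[C@@H](O[C@@H]2O[C@H](CO)[C@@H](O)[C@H](O)[C@H]2O)/C1=C/C`: > 15000 nM
Compound 2, `C/C=C1/[C@H](O[C@@H]2O[C@H](CO)[C@@H](O)[C@H](O)[C@H]2O)OC=C(C(=O)OC)[C@H]1CC(=O)OCCc1ccc(O)cc1`: > 20000 nM
Compound 3, `C/C=C1/[C@H](O[C@@H]2O[C@H](CO)[C@@H](O)[C@H](O)[C@H]2O)OC=C(C(=O)OC)[C@H]1CC(=O)OCCC1CCCCC1`: 2000 nM

Three compounds share one core and differ only in the group on a saturated chain carbon, two bonds along the chain from an oxygen next to a carbonyl group. In a functional assay on SK-BR-3 cells (Homo sapiens) for antiproliferative activity, read by MTT assay, with a stated time of 72 h (a lower number here means a stronger inhibitor, a higher number a weaker inhibitor), compound 1 reaches only a limit, > 15000 nM. Compound 2 likewise gives only a limit, > 20000 nM. Among the measured compounds shown here, compound 3 is the sole compound with a true number, 2000 nM, and so it stands alone among the values shown. Compound 4, `C/C=C1/[C@H](O[C@@H]2O[C@H](CO)[C@@H](O)[C@H](O)[C@H]2O)OC=C(C(=O)OC)[C@H]1CC(=O)OCCc1ccc(OC)c(OC)c1`, carries the change (3,4-dimethoxyphenyl in place of cyclohexyl on a saturated chain carbon, two bonds along the chain from an oxygen next to a carbonyl group). The step that bears on it runs the other way: an at least 10-fold lower number from compound 2 to compound 3 (1.00 log units; beyond the scatter). Replacing cyclohexyl with an aromatic ring thus cost potency in that one comparison, though its starting point was a limit (the limit of > 20000 nM in this assay, at which 1 of the 3 values shown sits), so the size is not fully known. A weaker result is expected for compound 4. The expected step is a 6.0-fold higher number from compound 3 to compound 4 (0.78 log units; beyond the scatter). Compound 4 is therefore estimated at 12000 nM, with a range from 3000 nM to 40000 nM.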

Compound 4, half-maximal inhibitory concentration: > 15000 nM
Compound 4: only a limit was reported (the forecaster's own chance of this, stated with the estimate: 45%); at least 1.2-fold (0.09 log units) between middle value and limit.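

In this assay, replacing cyclohexyl with 3,4-dimethoxyphenyl gives an at least 7.5-fold higher number from compound 3 to compound 4 (0.87 log units; beyond the scatter) and shows that the loss seen with 4-hydroxyphenyl in compound 2 is not confined to that one aromatic group. This step is only a minimum, since compound 4 reached just a limit, and that limit is shared with another compound here: the limit of > 15000 nM in this assay, at which 2 of the 4 values shown sit. Compound 1 also gives only a limit without any aromatic ring, so among these compounds the cyclohexyl of compound 3 stands out, rather than aromatic rings alone being the problem.

The steps among compounds 1, 2 and 4 cannot be read, which leaves their order unknown. Also open, as far as these compounds go, are whether unsubstituted phenyl behaves like 3,4-dimethoxyphenyl, and whether cyclopentyl or a longer chain ending in cyclohexyl keeps the activity of compound 3.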